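The compounds below may be only part of what the source reports. "The series", "measured", "known", "first", "only" and "open" are said of these compounds alone.

Measured set in a functional assay on cells (Cell line, Homo sapiens) for cytotoxicity; a higher number here means that more compound is tolerated, a lower number that less compound is tolerated:
compound 1 `O=C(C1CC1)N(O)c1ccc(Cl)cc1` gives 37 ug/mL;
compound 2 `O=C(CCC1CCCC1)N(O)c1ccc(Cl)cc1` gives 20 ug/mL;
compound 3 `O=C(CC1CCCCC1)N(O)c1ccc(Cl)cc1` gives 129 ug/mL.

Compound 2 holds the lowest of the three numbers in this assay. Its nearest neighbour is compound 1, within the scatter of it; compound 3 lies furthest away, beyond the scatter. The next step keeps the core of compound 2 and puts (cyclohexyl in place of cyclopentyl on a saturated chain carbon, two bonds along the chain from a carbonyl carbon), giving compound 4 `O=C(CCC1CCCCC1)N(O)c1ccc(Cl)cc1`. Among the compounds with values here, only one measured step bears on this: a 6.5-fold higher number from compound 2 to compound 3 (0.81 log units; beyond the scatter), which also shortens the chain, so it is a partial guide at best. Within the data shown here, no step changes ring size alone. A small rise beyond the scatter is expected, and compound 4 is estimated at 32 ug/mL (range 12 ug/mL to 85 ug/mL), an expected step of a 1.6-fold higher number from compound 2 to compound 4 (0.20 log units; within the scatter).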

Compound 4, half-maximal cytotoxic concentration: 4.7 ug/mL
Compound 4: middle estimate off by 6.8-fold (0.83 log units), on the high side; measured number outside the range, below it.
By their numbers in this assay, from the lowest: compound 4; then compounds 2 and 1 (each within the scatter of the next); then compound 3.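

In this assay, within the data shown here, cyclohexyl in place of cyclopentyl on a saturated chain carbon, two bonds along the chain from a carbonyl carbon, gives a 4.3-fold lower number from compound 2 to compound 4 (0.63 log units; beyond the scatter), the only step here that changes ring size alone. It runs opposite to a 6.5-fold higher number from compound 2 to compound 3 (0.81 log units; beyond the scatter), which also shortens the chain, so cyclohexyl alone does not set the direction of change across these compounds. No available evidence accounts for this difference. Open, going by these compounds, is whether a longer chain carrying cyclohexyl would lower the number further. Also open, on these data alone, is how an amine in that ring would shift it.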